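Swapping a Halogenated Phenyl on an Aromatic Amine

The source may hold more compounds than are shown below. What is called first, only, known or untested is meant among the compounds shown, and "the series" means these compounds.

Three compounds have been measured in a functional assay on NCI-H1975 cells (Homo sapiens) for inhibition, read by MTT assay, with a stated time of 72 h; on this read-out higher numbers stand for weaker inhibition and lower numbers for stronger inhibition:

Compound 1 `O=C(CSc1nc(Nc2ccccc2)c2ccccc2n1)Nc1ccc(Br)cc1`: 10600 nM
Compound 2 `O=C(CSc1nc(Nc2ccccc2)c2ccccc2n1)Nc1ccc(F)c(Cl)c1`: 9390 nM
Compound 3 `C=CC(=O)Nc1cccc(NC(=O)CSc2nc(Nc3ccccc3F)c3ccccc3n2)c1`: 6580 nM

Compound 3 shows the lowest of the three numbers, but compound 2 and compound 1 both lie within the scatter of it, so the three cannot be ranked. Compound 4 `C=CC(=O)Nc1cccc(NC(=O)CSc2nc(Nc3cccc(Cl)c3)c3ccccc3n2)c1` differs from compound 3 by 3-chlorophenyl in place of 2-fluorophenyl on a nitrogen on an aromatic ring. Among the measured compounds shown here, the only measured one-place step, a 1.1-fold lower number from compound 1 to compound 2 (0.05 log units; within the scatter), exchanged one halogenated phenyl for another on an amide-type nitrogen, a different place, and stayed within the scatter. For the measured compounds named here, no measured step touches the nitrogen changed here. A shift beyond the scatter is therefore not expected, so the expected step is a 1.0-fold lower number from compound 3 to compound 4 (0.01 log units; within the scatter). Compound 4 is estimated at 6500 nM, with a range from 2500 nM to 16000 nM.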

Compound 4, half-maximal inhibitory concentration: 9460 nM
Estimate against measurement, compound 4: 1.5-fold (0.16 log units) below, within the range that was stated.
By their numbers in this assay, from the lowest: compounds 3, 2, 4 and 1 (each within the scatter of the next).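

In this assay, among the compounds shown here, the first measured change on this nitrogen, (2-fluorophenyl)amino to (3-chlorophenyl)amino, gives a 1.4-fold higher number from compound 3 to compound 4 (0.16 log units; within the scatter) and so leaves the two compounds unranked. At this place, then, exchanging one halogenated phenyl for another did not move the number beyond the scatter, just as the earlier exchange on the amide-type nitrogen did not. Nothing available explains this result. Going by these compounds, what stays open is whether a different kind of group on this nitrogen, such as a phenyl carrying a carboxylic acid or a longer alkyl chain, would shift the number beyond the scatter.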